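From compound 2 to compound 4: a new ether chain

A few compounds are considered here, and "the series" means these few. Any claim that something is new, unique, unknown or untested is made for them only; others in the source may bear on it.

Compound 1 `CC(C)=CCOc1cccc(Nc2nccs2)c1`: 23000 nM
Compound 2 `CC(C)=CCOc1cc(Nc2nccs2)ccc1Cl`: 26000 nM
Compound 3 `CC(C)=CCOc1cc(Nc2nccs2)ccc1C(=O)O`: 17000 nM

These values come from a functional assay on MT2 cells (Homo sapiens) for cytotoxicity, read by MTT assay; on this read-out higher numbers stand for lower toxicity in this test and lower numbers for higher toxicity in this test. Compound 2, at 26000 nM, cannot be told apart from the other two compounds, as every gap among the three lies within the scatter.

Compound 4 `Clc1ccc(Nc2nccs2)cc1OCC1CCCCC1` differs from compound 2 only in the chain on the oxygen: cyclohexyl in place of 2-methylprop-1-en-1-yl on a saturated chain carbon bound to an oxygen on an aromatic ring. In other words, 3-methylbut-2-en-1-yl gives way to cyclohexylmethyl.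

The measured steps are a 1.1-fold higher number from compound 1 to compound 2 (0.05 log units; within the scatter), a 1.4-fold lower number from compound 1 to compound 3 (0.13 log units; within the scatter) and a 1.5-fold lower number from compound 2 to compound 3 (0.18 log units; within the scatter). All three are swaps on an aromatic carbon, so they bear on this chain change only indirectly. Within the data shown here, no measured compound here carries a different chain, which leaves no direct guide.

Compound 2, at 26000 nM, is therefore the starting point, and no step beyond the scatter is expected in this assay. The expected change is a 1.2-fold lower number from compound 2 to compound 4 (0.07 log units; within the scatter), with its direction left open. For compound 4 the estimated value is 22000 nM, with an expected range from 9000 nM to 50000 nM.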

Compound 4, half-maximal cytotoxic concentration: 15000 nM
Beside the measured number, compound 4's estimate is 1.5-fold (0.17 log units) above it; the measured number falls inside the stated range.
By their numbers in this assay, from the lowest: compounds 4, 3, 1 and 2 (each within the scatter of the next).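

Among these compounds, this is the first change in the chain on the oxygen rather than on the aromatic ring, and replacing 3-methylbut-2-en-1-yl with cyclohexylmethyl gives (a 1.7-fold lower number from compound 2 to compound 4 (0.24 log units; within the scatter)) in this assay. The step stays within the scatter, so at this position a chain with a six-membered non-aromatic ring of carbon only and an open chain with a double bond cannot be told apart in this test. Nothing in the available data offers an explanation for this result.

A single swap cannot show how far this tolerance extends, so a chain ending in an amine, a carboxylic acid or a longer straight chain on the same oxygen remains an open case. Also open, going by these compounds, is whether cyclohexylmethyl would read the same with hydrogen or carboxy in place of the chloro.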